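Isopropyl to chloro: one step in the series

The source may hold more compounds than are shown below. What is called first, only, known or untested is meant among the compounds shown, and "the series" means these compounds.

Values in an ADME assay on a cell-free system (plasma, Mus musculus) (a lower number here means a smaller unbound share, a higher number a larger unbound share of the compound), for the compounds measured so far:
- compound 1 `CC(C)S(=O)(=O)c1ccc(Cl)c(C#Cc2cc(Cl)ccc2OCC(=O)O)c1` gives "not determined" (no result reported)
- compound 2 `CN(C)S(=O)(=O)c1cncc(C#Cc2cc(Cl)ccc2OCC(=O)O)c1` gives 0.034
- compound 3 `CC(C)c1ccc(S(C)(=O)=O)cc1C#Cc1cc(Cl)ccc1OCC(=O)O` gives 0.013

Compound 3 holds the lower of the two numbers available, and compound 2 stands above it by a gap beyond the usual scatter. For the measured compounds named here, compound 1 offers no number, so only two values anchor the series.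

The next compound is compound 4 `CS(=O)(=O)c1ccc(Cl)c(C#Cc2cc(Cl)ccc2OCC(=O)O)c1`, which carries chloro in place of isopropyl on an aromatic carbon. The change is chloro in place of isopropyl on an aromatic carbon and it sits ortho to a large group and para to a methylsulfonyl group.

Going by the values given here, no measured pair shows this exchange, so the expectation is loose. Among the compounds with values here, the one guide is that compound 2, which has no isopropyl group, reads 0.034 in this assay and so lies higher than compound 3. A modest rise is expected, and the estimated step of a 1.8-fold higher number from compound 3 to compound 4 (0.27 log units; within the scatter) stays close to the edge of the scatter. Compound 4 is estimated at 0.024 with an expected range of 0.011 to 0.05 in this series.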

Compound 4, unbound fraction: 0.025
Estimate against measurement, compound 4: 1.0-fold (0.02 log units) below, and the stated range covers the measured number.
By their numbers in this assay, from the lowest: compounds 3, 4 and 2 (each within the scatter of the next, the first and the last beyond it).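

For the compounds shown here, compound 3 and compound 4 form the first pair that differs in one place, so this exchange can now be read directly. In this assay, chloro in place of isopropyl on an aromatic carbon, ortho to a large group and para to a methylsulfonyl group, gives a 1.9-fold higher number from compound 3 to compound 4 (0.28 log units; within the scatter), so for this pair, 3 heavy atoms can leave and 1 heavy atom can enter at this position without a step beyond the scatter. No supporting data bear on why the step has this size.

From the compounds shown here alone, this single pair covers only isopropyl and chloro at this position, so it remains open how an amine, a methoxy group, a nitrile, a carboxylic acid or a longer chain such as n-butyl would read there in this assay. Going by these compounds, it also remains open whether the exchange of isopropyl for chloro would give a similar step with an ethylsulfonyl or a sulfonamide group in place of the methylsulfonyl group.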